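Methoxy to methyl: expected cost in cytotoxicity

The source may report more compounds than this note shows. Statements on the series, on what has been measured and on what is new or still open speak of the compounds shown alone.

Within the data shown here, compound 2 `COc1ccc(/C=C2\S/C(=N\c3nc(-c4c(C)n(C)n(-c5ccccc5)c4=O)cs3)N(c3ccccc3)C2=O)cc1` carries the only numeric value in this set; in a functional assay on A549 cells (Homo sapiens) for cytotoxicity, read by sulforhodamine B assay, with a stated time of 72 h (a higher number here means a weaker inhibitor, a lower number a stronger inhibitor), compound 2 gives 9100 nM. Compound 1 `Cc1c(-c2csc(/N=C3\S/C(=C\c4ccccc4)C(=O)N3c3ccccc3)n2)c(=O)n(-c2ccccc2)n1C` returns only > 100000 nM in this assay, which is a limit and not a number (the limit of > 100000 nM in this assay, at which 1 of the 2 values shown sits). Compound 3 `Cc1ccc(/C=C2\S/C(=N\c3nc(-c4c(C)n(C)n(-c5ccccc5)c4=O)cs3)N(c3ccccc3)C2=O)cc1` differs from compound 2 by methyl in place of methoxy on an aromatic carbon. Among the measured compounds shown here, the single measured step, an at least 10-fold lower number from compound 1 to compound 2 (1.04 log units; beyond the scatter), involves the same aromatic carbon and shows that the group there matters, so the move to methyl is expected to raise the number moderately, a 2.7-fold higher number from compound 2 to compound 3 (0.44 log units; beyond the scatter), with the size uncertain. Compound 3 is estimated at 25000 nM, within 8000 nM to 80000 nM.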

Compound 3, half-maximal inhibitory concentration: > 100000 nM
Compound 3 was reported as a limit (the forecaster's own chance of this, stated with the estimate: 20%); middle value at least 4.0-fold (0.60 log units) away from the limit.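

Methoxy is now the only group at this aromatic carbon that gives a number in this assay, and replacing it with methyl loses that reading (an at least 10-fold higher number from compound 2 to compound 3 (1.04 log units; beyond the scatter)). The gain seen with methoxy over hydrogen is therefore not shared by methyl, so the effect depends on which group sits here, not simply on hydrogen being replaced. The step between the two other compounds cannot be read, and the data at this position are bounded by a limit: the limit of > 100000 nM in this assay, at which 2 of the 3 values shown sit.

From the compounds shown here alone, whether the oxygen of methoxy is needed remains open, as hydroxy, ethoxy or an amine at this carbon could show. Going by these compounds, whether a longer chain here improves on compound 2 also remains open.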